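The compounds below may be only part of what the source reports. "The series", "measured", "known", "first", "only" and "open" are said of these compounds alone.

Among the measured compounds shown here, in a functional assay on HeLa cells (Homo sapiens) for antiproliferative activity, read by MTT assay, with a stated time of 48 h (on this read-out higher numbers stand for weaker inhibition and lower numbers for stronger inhibition), compound 3 `C=C(c1cc(OC)c(OC)c(OC)c1)c1ccc(OC)cc1NC(=O)CN` gives 70 nM and sits in the middle of the three numbers so far. Compound 2 `C=C(c1cc(OC)c(OC)c(OC)c1)c1ccc(OC)cc1NC(=O)CO` gives 30 nM on the lower side, and compound 1 `COc1ccc(C(=O)c2ccc(OC)c3c2OC(C)(C)C=C3)c(NC(=O)CN)c1` gives 410 nM on the higher side. Compound 4 `C=C(c1cc(OC)c(OC)c(OC)c1)c1ccc(OC)cc1NC(=O)CNC` alters compound 3 in one place, with methyl in place of hydrogen on an amine nitrogen is the whole difference. For the measured compounds named here, no measured step makes this exact change. The closest one, a 2.3-fold higher number from compound 2 to compound 3 (0.37 log units; beyond the scatter) and modest in size, puts that amino group in place of hydroxy, so it is only a loose guide. A small rise in the number, meaning weaker inhibition, is therefore expected in this assay and no large jump. The estimated move is a 1.7-fold higher number from compound 3 to compound 4 (0.23 log units; within the scatter) here. Compound 4 is estimated at 120 nM with a range from 40 nM to 350 nM as the expected span.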

Compound 4, half-maximal inhibitory concentration: 140 nM
Compound 4: the middle estimate sits 1.2-fold (0.07 log units) below what was measured; measured number inside the range.
By their numbers in this assay, from the lowest: compound 2; then compounds 3 and 4 (each within the scatter of the next); then compound 1.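

In this assay, methyl in place of hydrogen on the amine nitrogen gives a 2.0-fold higher number from compound 3 to compound 4 (0.30 log units; within the scatter) and so stays within the usual scatter, which means this nitrogen can carry one added carbon without a change that can be told apart from repeat-measurement noise. Methylamino in place of hydroxy on the saturated chain carbon bound to a carbonyl carbon gives a 4.7-fold higher number from compound 2 to compound 4 (0.67 log units; beyond the scatter) and is a real, modest loss. No measurement here explains these numbers. The compounds shown leave open how a dimethylamino group or a longer chain such as ethyl on this nitrogen would read. They also leave open whether the same methyl would behave alike on the core of compound 1.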